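This account rests on a few compounds, and the source may have more. Where it says the series, first, only, none or still open, it means among the compounds named here.

Measured in an ADME assay on MDCK cells (Canis lupus familiaris) for permeability, read by LC-MS, with a stated time of 90 min, tested at 2 uM; on this read-out higher numbers stand for higher permeability and lower numbers for lower permeability:
- compound 1 `COc1cc(C)[nH]c(=O)c1CN1CCc2c(Cl)cc(-c3c(C)noc3C)c(Cl)c2C1=O`: 11 10^-6 cm/s
- compound 2 `Cc1cc(C)c(CN2CCc3c(Cl)cc(C(CO)c4ccon4)c(Cl)c3C2=O)c(=O)[nH]1`: 5.8 10^-6 cm/s; 8.6 10^-6 cm/s (2 entries)
- compound 3 `CCOC(c1cc(Cl)c2c(c1Cl)C(=O)N(Cc1c(C)cc(C)[nH]c1=O)CC2)C1CS(=O)(=O)C1`: 12 10^-6 cm/s; 7.7 10^-6 cm/s (2 entries)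

Compound 1 rests on a single number, while the other two compounds have two entries each: the several entries of compound 2 in this assay, 5.8 10^-6 cm/s; 8.6 10^-6 cm/s (2 entries) and (the several entries of compound 3 in this assay, 12 10^-6 cm/s; 7.7 10^-6 cm/s (2 entries)). Its value lies within the scatter of those entries.

Compound 4 `COc1cc(C)[nH]c(=O)c1CN1CCc2c(Cl)cc([C@@H](O)C3COC3)c(Cl)c2C1=O` keeps the core of compound 1 but loses the 3,5-dimethyl-1,2-oxazol-4-yl group on the aromatic carbon: a group of 6 heavy atoms (4 carbon, 2 oxygen; one four-membered non-aromatic ring with 1 hetero atom) in place of a group of 7 heavy atoms (5 carbon, 1 nitrogen, 1 oxygen; one five-membered aromatic ring with 2 hetero atoms), on an aromatic carbon. Within the data shown here, no measured step in this assay covers this change, so the expectation rests only on the narrow spread of the three compounds. A small fall is expected: a 1.7-fold lower number from compound 1 to compound 4 (0.23 log units; within the scatter). For compound 4 the estimated value is 6.5 10^-6 cm/s, with an expected range of 3.5 10^-6 cm/s to 12 10^-6 cm/s.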

Compound 4, apparent permeability in the MDCK assay: 1.2 10^-6 cm/s
Compound 4: middle estimate off by 5.4-fold (0.73 log units), on the high side; the measured number lies below the stated range.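

Among these compounds, in the MDCK assay, this aromatic carbon proves sensitive to the change of group, with a 9.2-fold lower number from compound 1 to compound 4 (0.96 log units; beyond the scatter), which the earlier compounds, with no step between them, could not show. The entering group carries a hydrogen-bond donor and a defined stereocentre, which the 3,5-dimethyl-1,2-oxazol-4-yl group lacks. In a physicochemical assay for lipophilicity, at pH 7.4 (on this read-out higher numbers stand for higher lipophilicity and lower numbers for lower lipophilicity), compound 1 gives 2.7 and compound 4 gives 1.3 on the same read-out. The same change also lowers lipophilicity in the physicochemical assay: the measured distribution coefficient of compound 1, 2.7, and of compound 4, 1.3, a number 1.40 log units lower (beyond the scatter)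

This single pair cannot separate the contributions of the donor, the ring and the lipophilicity to the fall. From the compounds shown here alone, what a pyridine ring on this aromatic carbon would give in the MDCK assay stays open.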